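Dimethylamino in Place of Acetyl on the Shared Core

The compounds below may be only part of what the source reports. "The series", "measured", "known", "first", "only" and "open" are said of these compounds alone.

Of the compounds shown here, three built on a shared core have been measured in a functional assay on HOP-92 cells (Homo sapiens) for cytotoxicity, read by sulforhodamine B assay, with a stated time of 48 h, tested at 10 uM; a lower number here means a stronger effect, a higher number a weaker effect of the compound at the concentration tested. Compound 1, `COc1cc(C)cc(-c2c(-c3ccnc(-c4ccc(C(C)=O)cc4)c3)cnn2CC#N)c1`, gives -1% in this assay. Compound 2, `COc1cc(C)cc(-c2nn(CC#N)cc2-c2ccc(-c3cccc(C(C)=O)c3)nc2)c1`, gives -17% in this assay, and compound 3, `Cc1cc(O)cc(-c2nn(CC#N)cc2-c2ccnc(-c3ccc(Oc4ccccc4)cc3)c2)c1`, gives -65% in this assay. Among these three numbers compound 1 stands highest, which in this assay means the weakest effect at the concentration tested: compound 2 is nearest to it, with a lower number that lies beyond the scatter, and compound 3 is furthest from it, with a lower number that also lies beyond the scatter.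

The fourth compound, compound 4, `COc1cc(C)cc(-c2c(-c3ccnc(-c4ccc(N(C)C)cc4)c3)cnn2CC#N)c1`, has not yet been measured. It differs from compound 1 in one place: dimethylamino in place of acetyl on an aromatic carbon on an aromatic carbon of a six-membered aromatic ring of carbon only, para to a large group; cut one bond further out, the change reads 4-acetylphenyl to 4-(dimethylamino)phenyl. For the measured compounds named here, no pair among the measured compounds isolates this change, so nothing in the data sets its size. The account expects a small step, if any, toward a lower number, a number 9 percentage points lower from compound 1 to compound 4 (within the scatter), but nothing beyond the scatter is demanded. For compound 4 the estimated value in this assay is -10%, expected to fall between -40% and 12%.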

Compound 4, a percentage reported as activity, at one concentration (the size of the read-out at that concentration, not a potency): -26%
For compound 4 the middle estimate is 16 percentage points above the measured one, within the range that was stated.
By their numbers in this assay, from the lowest: compound 3; then compounds 4 and 2 (each within the scatter of the next); then compound 1.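

For the compounds shown here, replacing 4-acetylphenyl with 4-(dimethylamino)phenyl is the first change in a single place that can be read in this assay, and the step is a number 25 percentage points lower from compound 1 to compound 4 (beyond the scatter). It shows that this position, on an aromatic carbon para to a large group, is not indifferent to what it carries: the rest of the shared core stays the same, and the two groups match in their counts of heavy atoms, hydrogen-bond donors and hydrogen-bond acceptors, with no net charge on either, yet the read-out still moves. Nothing presented here bears on what lies behind this step.

Going by these compounds, this single pair cannot separate what dimethylamino brings from what the loss of acetyl removes, so it remains open how a primary amine, a morpholine ring or a carboxylic acid would read at the same place. On these data alone, it also remains open whether a longer chain on the nitrogen, as in diethylamino, would take the number further in the same direction or bring it back.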